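Notes on tolerated concentration in a small aryl ether series

A few compounds are considered here, and "the series" means these few. Any claim that something is new, unique, unknown or untested is made for them only; others in the source may bear on it.

Measured so far:
- compound 1 `Cc1cc(/C=C/C#N)cc(C)c1Oc1nc(Nc2ccc(N3CCCC(N)C3)cc2)nc2ccsc12`: 3820 nM
- compound 2 `Cc1cc(/C=C/C#N)cc(C)c1Oc1nc(Nc2ccc(CN3CCNCC3)cc2)nc2sccc12`: 4030 nM

Both numbers come from an ADME assay on MT4 cells (Homo sapiens) for cytotoxicity, read by MTT assay, with a stated time of 5 days; a higher number here means that more compound is tolerated, a lower number that less compound is tolerated. Compound 1 stands at the lowest of the two numbers, but the nearest number, that of compound 2, lies within the scatter of it, so the two compounds cannot be placed in any order on this read-out; they are, for working purposes, equal.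

Compound 3 `Cc1cc(/C=C/C#N)cc(C)c1Oc1nc(Nc2ccc(N3CCNCC3)cc2)nc2ccsc12` has not yet been measured. It differs from compound 1 in one place: piperazin-1-yl in place of 3-aminopiperidin-1-yl on an aromatic carbon. Within the data shown here, no step between two measured compounds that differ in only one place is available, so there is no measured step on which to lean. The two measured compounds carry different groups at the same kind of position and still sit within the scatter of each other, which gives no sign that this part of the structure moves the read-out. The step from compound 1 to compound 3 in this assay is therefore expected to stay within the scatter, in no particular direction.

Compound 3 is estimated at 4000 nM, with a range from 2000 nM to 8000 nM. The step this estimate implies, a 1.0-fold higher number from compound 1 to compound 3 (0.02 log units; within the scatter), is expected to be small.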

Compound 3, half-maximal cytotoxic concentration: 5730 nM
Compound 3: middle estimate off by 1.4-fold (0.16 log units), on the low side, within the range that was stated.
By their numbers in this assay, from the lowest: compounds 1, 2 and 3 (each within the scatter of the next).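

In this assay, among these compounds, the exchange of 3-aminopiperidin-1-yl for piperazin-1-yl on an aromatic carbon, para to a large group, gives the first step in which only this one group changes (a 1.5-fold higher number from compound 1 to compound 3 (0.18 log units; within the scatter)). On this read-out, the two six-membered non-aromatic rings therefore cannot be told apart on the shared core, and this direct comparison now supports what could previously be judged only from compounds differing in more than one place. No measurement at hand bears on why the step has this size.

Among the compounds shown here, the single step covers only one exchange between two cyclic amines, so it does not show whether the tolerated concentration stays within the scatter for groups of other kinds at this aromatic carbon, such as a morpholin-4-yl ring, a carboxylic acid or a longer aminoalkyl chain. It also leaves open whether the same exchange would give a similar step on a different core, or whether any group at this position can move the number beyond the scatter in this assay.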